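A few compounds are considered here, and "the series" means these few. Any claim that something is new, unique, unknown or untested is made for them only; others in the source may bear on it.

Three compounds share a core: compound 1 `CC(C)(C)c1cc(NC(=O)Nc2ccc(-c3nc4ccccc4o3)cc2)no1`, compound 2 `CC(C)(C)c1cc(NC(=O)Nc2ccc(-c3cn4cccc(F)c4n3)cc2)no1` and compound 3 `CC(C)(C)c1cc(NC(=O)Nc2ccc(-c3cn4ccc(Br)cc4n3)cc2)no1`. In a functional assay on MV4-11 cells (Homo sapiens) for cytotoxicity, read by MTT assay, with a stated time of 72 h (a lower number here means a stronger inhibitor, a higher number a weaker inhibitor), compound 1 gives 82.6 nM, compound 2 gives 12.2 nM, and compound 3 gives 9.59 nM. Compound 3 holds the lowest number of the three; its gap to compound 2 lies within the scatter, its gap to compound 1 beyond it. Compound 4 `CCOc1ccn2cc(-c3ccc(NC(=O)Nc4cc(C(C)(C)C)on4)cc3)nc2c1` differs from compound 3 in one place: ethoxy in place of bromo on an aromatic carbon. Going by the values given here, no step of this kind has been measured. Compound 2 and compound 3 both sit low with different groups on that ring; how an ethoxy behaves there is not known. In this assay the step is expected to be small, possibly a slight weakening, not clearly beyond the scatter. Compound 4 is therefore estimated at 16 nM (range 5 nM to 50 nM). The expected step is a 1.7-fold higher number from compound 3 to compound 4 (0.22 log units; within the scatter).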

Compound 4, half-maximal inhibitory concentration: 11.6 nM
The estimate for compound 4 lay 1.4-fold (0.14 log units) above the measured number; the measured number falls inside the stated range.
By their numbers in this assay, from the lowest: compounds 3, 4 and 2 (each within the scatter of the next); then compound 1.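

In this assay, ethoxy in place of bromo gives a 1.2-fold higher number from compound 3 to compound 4 (0.08 log units; within the scatter), so the aromatic carbon opposite the ring nitrogen accepts ethoxy, with its 3 heavy atoms and 1 hydrogen-bond acceptor, with no step beyond the scatter. Going by these compounds alone, this single pair is the first direct reading at this position, and it shows that the low number of compound 3 does not depend on bromo specifically.

As far as these compounds go, whether a longer chain such as butoxy, or an amine or a carboxylic acid, would hold up on the same carbon remains open. No evidence at hand explains why the two groups read alike.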